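Nitro to fluoro: working notes on compound 4

This account rests on a few compounds, and the source may have more. Where it says the series, first, only, none or still open, it means among the compounds named here.

Within the data shown here, in a functional assay on A549 cells (Homo sapiens) for antiproliferative activity, read by sulforhodamine B assay, with a stated time of 48 h (a higher number here means a weaker inhibitor, a lower number a stronger inhibitor), compound 2 (`COc1cc(OC)c2sc(-c3ccc(N/C=C\C(=O)c4ccc(OC)c([N+](=O)[O-])c4)cc3)nc2c1`) gives 5800 nM and stands lowest of the three numbers so far. Compound 1 (`COc1cc(OC)c2sc(-c3ccc(N/C=C\C(=O)c4ccc(OC)c([N+](=O)[O-])c4)c(C)c3)nc2c1`) gives 12100 nM in the same read-out and compound 3 (`COc1ccc(C(=O)/C=C\Nc2ccc(-c3nc4cc(OC)c(OC)c(OC)c4s3)cc2)cc1[N+](=O)[O-]`) gives 21200 nM there. Among the measured compounds shown here, compound 4 (`COc1cc(OC)c2sc(-c3ccc(N/C=C\C(=O)c4ccc(OC)c(F)c4)cc3)nc2c1`) carries fluoro in place of nitro on an aromatic carbon as its one change from compound 2. The measured steps of a 2.1-fold lower number from compound 1 to compound 2 (0.32 log units; beyond the scatter) and a 3.7-fold higher number from compound 2 to compound 3 (0.56 log units; beyond the scatter) are both modest and neither touches the nitro group, so they suggest a size but no direction. On these data alone, no step beyond the scatter is expected as the central case, though a modest step either way stays open. The estimated step is a 1.0-fold higher number from compound 2 to compound 4 (0.01 log units; within the scatter) in this assay on this reading. For compound 4 the expected value is 6000 nM with an estimated range from 1800 nM to 20000 nM in this read-out.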

Compound 4, half-maximal inhibitory concentration: 5300 nM
Beside the measured number, compound 4's estimate is 1.1-fold (0.05 log units) above it; the range from low to high includes it.
By their numbers in this assay, from the lowest: compounds 4 and 2 (each within the scatter of the next); then compounds 1 and 3 (each within the scatter of the next).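

In this assay the change from 4-methoxy-3-nitrophenyl to 3-fluoro-4-methoxyphenyl gives a 1.1-fold lower number from compound 2 to compound 4 (0.04 log units; within the scatter) and is the first step shown at this position, ortho to a methoxy group. In this one pair, the three heavy atoms of nitro and its two hydrogen-bond acceptors can give way to the single atom of fluoro with no step beyond the scatter. No measurement at hand bears on why the two numbers lie so close.

On these data alone, how an amine or a carboxylic acid would read at this position stays open. So does whether fluoro in place of nitro gives a similar step on the cores of compound 1 and compound 3.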